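This account rests on a few compounds, and the source may have more. Where it says the series, first, only, none or still open, it means among the compounds named here.

- compound 1 `COC(=O)Nc1cc(-c2ccc(OC[C@@](C)(N)CC(C)C)cn2)ccn1`: 100%
- compound 2 `COC(=O)Nc1cc(-c2cnc(OC[C@@](C)(N)CC(C)C)c(Cl)c2)ccn1`: 73%
- compound 3 `COC(=O)Nc1cc(-c2ccc(OC[C@@](C)(N)CC(C)C)c(Cl)n2)ccn1`: 99%

In an ADME assay on microsomes from liver (Rattus norvegicus) for metabolic stability, read by LC-MS, using NADPH, with a stated time of 10 min, tested at 0.5 uM (on this read-out lower numbers stand for a less stable compound and higher numbers for a more stable compound), compound 1 gives 100% and sits at the top of the numbers shown, level within the scatter with compound 3. Both stand clear of compound 2, and that gap lies beyond the scatter.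

Compound 4 `COC(=O)Nc1cc(-c2cc(Cl)c(OC[C@@](C)(N)CC(C)C)cn2)ccn1` has not been measured yet. It differs from compound 1 in one place: chloro in place of hydrogen on an aromatic carbon. This is chloro in place of hydrogen on an aromatic carbon, ortho to the (2-amino-2,4-dimethylpentyl)oxy group and opposite the ring nitrogen.

Going by the values given here, the one measured step of the same kind, with the chloro at a different place, is a number 1 percentage points lower from compound 1 to compound 3 (within the scatter). That points to no change beyond the scatter in this assay. Some room downward remains. Among the compounds with values here, the chloro is not the only difference between compound 1 and compound 2, and compound 2 reads 73%.

The expected step is a number 7 percentage points lower from compound 1 to compound 4 (within the scatter), which stays within the scatter. For compound 4 the estimated value is 93%, with an expected range of 75% to 100%.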

Compound 4, percent of the compound remaining: 99%
Compound 4: the middle estimate sits 6 percentage points below what was measured, within the range that was stated.
By their numbers in this assay, from the lowest: compound 2; then compounds 3, 4 and 1 (each within the scatter of the next).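

In this assay, placing chloro on the aromatic carbon ortho to the (2-amino-2,4-dimethylpentyl)oxy group and opposite the ring nitrogen gives a number 1 percentage points lower from compound 1 to compound 4 (within the scatter). Alongside a number 1 percentage points lower from compound 1 to compound 3 (within the scatter), this shows that the same swap of hydrogen for chloro at a second place on this ring also causes no change beyond the scatter, so the earlier result is not limited to a single place. No measurement shown here explains why the compound's stability holds at this position.

Chloro is the only replacement for hydrogen shown at this position, so the outcome with a fluoro, a methyl or a methoxy group there remains open. Since compound 1 already gives 100%, this read-out has little room to show any gain in stability from such a change.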